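This account rests on a few compounds, and the source may have more. Where it says the series, first, only, none or still open, it means among the compounds named here.

Measured in a functional assay on NCI-H522 cells (Homo sapiens) for cytotoxicity, with a stated time of 3 days; on this read-out lower numbers stand for stronger inhibition and higher numbers for weaker inhibition:
Compound 1 `C#Cc1nc(C(=O)N2CCN(c3ccc(Cl)cc3)CC2)cs1`: 28 nM
Compound 2 `C#CCNC(=O)c1csc(C#Cc2ccccc2)n1`: > 40000 nM (a limit)
Compound 3 `Cn1cnc2ccccc21`: > 40000 nM (a limit)

Compound 2 has no exact number. In this assay compound 2 reads > 40000 nM, and this is a limit of the assay. The same limit applies to compound 3, so the data show (the limit of > 40000 nM in this assay, at which 2 of the 3 values shown sit). Compound 2 therefore cannot be ranked against compound 3.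

The next compound to be tested is compound 4 `C#CCNC(=O)c1csc(C#C)n1`. It keeps the rest of compound 2 and changes in one place: hydrogen in place of phenyl on a triple-bonded carbon. In words, this puts hydrogen in place of phenyl on a triple-bonded carbon.

Among the compounds with values here, no measured step between close relatives shows what this change does. Within the data shown here, the only guide is that compound 1 also has hydrogen on a triple-bonded carbon, and compound 1 gives 28 nM. Compound 1 differs from compound 4 elsewhere, so this comparison is weak. Even so, a gain in strength well beyond the scatter is expected, although a result that stays at the limit remains possible. The expected change is the estimated step of an at least 20-fold lower number from compound 2 to compound 4 (1.30 log units; beyond the scatter). For compound 4 the estimated value is 2000 nM, with an expected range of 100 nM to 30000 nM.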

Compound 4, half-maximal inhibitory concentration: 2100 nM
The estimate for compound 4 lay 1.1-fold (0.02 log units) below the measured number, and the stated range covers the measured number.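

In this assay, within the data shown here, this is the first measured change at this position between two compounds that differ in one place: an at least 19-fold lower number from compound 2 to compound 4 (1.27 log units; beyond the scatter). It shows that the group on this triple-bonded carbon matters, since swapping phenyl for hydrogen, with the rest of the molecule unchanged, takes the compound from no measured inhibition to a real number. The step is stated as a minimum, since compound 2, at one end of it, is a limit: the limit of > 40000 nM in this assay, at which 2 of the 4 values shown sit.

Only hydrogen and phenyl are seen on this carbon, so the compounds shown cannot say whether the gain needs hydrogen itself or only the absence of phenyl, and a methyl group or a short hydroxymethyl chain in that place would help to tell these apart. They also leave open what the rest of the molecule contributes, for instance how an amine or a carboxylic acid would behave in place of the chain on the amide of compound 4, and why the phenyl change has the effect it does.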